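This account rests on a few compounds, and the source may have more. Where it says the series, first, only, none or still open, it means among the compounds named here.

Compound 1 `Cc1c(OCCCCOCOc2ccc(C(=O)O)cc2)ccc(C(=O)CC2CCCC2)c1O` is the starting point, and the measure followed here is an ADME assay (liver) for metabolic stability, with Liver microsome (Rattus norvegicus) as the target, read by LC-MS, using microsomes and NADPH, with stated times of 5 min and 60 min, tested at 4 uM; a lower number here means that less of the compound is left, a higher number that more of the compound is left. Among the measured compounds shown here, in this test compound 1 gives 31%, which places it in the middle of the three compounds measured so far. Compound 3 `Cc1cc(OCCCCOc2ccc(C(=O)CC(C)C)c(O)c2C)ccc1C(=O)O` stands higher at 57% and compound 2 `CCCC(=O)c1ccc(OCCCCOc2cc(C(=O)O)ccc2OC)c(C)c1O` stands lower at 1%, and both gaps from compound 1 lie beyond the usual scatter.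

The next compound, compound 4 `Cc1cc(C(=O)O)ccc1OCCCCOc1ccc(C(=O)CC2CCCC2)c(O)c1C`, has not yet been measured. It differs from compound 1 in one place, on an oxygen on a saturated carbon, where 4-carboxy-2-methylphenyl stands in place of (4-carboxyphenoxy)methyl (4-carboxy-2-methylphenyl in place of (4-carboxyphenoxy)methyl on an oxygen on a saturated carbon).

For the measured compounds named here, no two measured compounds differ in only one place, so there is no direct step to serve as a guide. Compound 2 and compound 3 also lack the (4-carboxyphenoxy)methyl group, yet their results lie far apart, with compound 2 at 1% and compound 3 at 57%. Losing that group therefore gives no firm direction. The expected change, a number 9 percentage points higher from compound 1 to compound 4 (within the scatter), is a small rise that may well stay within the scatter. For compound 4 the estimated value is 40%, with an expected range from 12% to 68%.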

Compound 4, percent of the compound remaining: 59%
Compound 4: middle estimate off by 19 percentage points, on the low side, within the range that was stated.
By their numbers in this assay, from the lowest: compound 2; then compound 1; then compounds 3 and 4 (each within the scatter of the next).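

Among the compounds shown here, at this position, on an oxygen on a saturated carbon, putting 4-carboxy-2-methylphenyl in place of (4-carboxyphenoxy)methyl gives the first direct comparison in this assay, with a change of a number 28 percentage points higher from compound 1 to compound 4 (beyond the scatter). The earlier compounds shown here differ from one another in more than one place, whereas here a rise that lies beyond the scatter can be tied to a single place, with the rest of the structure unchanged. Nothing measured here explains why more of compound 4 is left after incubation with the microsomes.

The swap changes more than one feature at once: the heavy-atom count of the group changes, and the entering ring carries a methyl, so the step alone does not separate these changes. A plain 4-carboxyphenyl on the same oxygen would help to separate them, and an amide in place of the carboxylic acid would test whether the result depends on that acid.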